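This account rests on a few compounds, and the source may have more. Where it says the series, first, only, none or still open, it means among the compounds named here.

Measured so far:
compound 1 `CN(C)c1ncnc2c1c(-c1ccsc1)cn2[C@@H]1O[C@H](CO)[C@@H](O)[C@H]1O` — 1920 nM
compound 2 `CNc1ncnc2c1c(-c1cccs1)cn2[C@@H]1O[C@H](CO)[C@@H](O)[C@H]1O` — > 20000 nM

Both compounds were tested in a functional assay on HL-60 cells (Homo sapiens) for antiproliferative activity, read by XTT assay, with a stated time of 72 h; a lower number here means a stronger inhibitor, a higher number a weaker inhibitor. Compound 1 gives 1920 nM in this assay. For compound 2 the result is only a limit of the assay, > 20000 nM in this assay, not a number. Compound 2 thus stands at the limit of > 20000 nM in this assay, at which 1 of the 2 values shown sits. Within the data shown here, compound 1 and compound 2 differ in more than one place, so their two values show only that one gives a number and the other a limit.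

Compound 3 `CN(C)c1ncnc2c1c(-c1cccs1)cn2[C@@H]1O[C@H](CO)[C@@H](O)[C@H]1O` has not yet been measured in this assay. It differs from compound 2 by methyl in place of hydrogen on a nitrogen on an aromatic ring. Among the measured compounds shown here, no step between measured compounds is available, so the size of this change cannot be read from the data. Compound 1, which also carries the dimethylamino group, gives 1920 nM in this assay, and on that basis a step toward stronger inhibition is expected. Whether compound 3 moves away from the limit at which compound 2 sits cannot be told from the data. The expected step is an at least 3.3-fold lower number from compound 2 to compound 3 (0.52 log units; beyond the scatter). Compound 3 is estimated at 6000 nM, within a range from 1500 nM to 25000 nM.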

Compound 3, half-maximal inhibitory concentration: 11800 nM
Compound 3: middle estimate off by 2.0-fold (0.29 log units), on the low side; low and high end bracket the measured number.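

From the compounds shown here alone, changing methylamino to dimethylamino on the thiophen-2-yl compounds can now be read in this assay, and the result is an at least 1.6-fold lower number from compound 2 to compound 3 (0.22 log units; that floor lies within the scatter), so the change can be given only as a floor and its true size remains unknown. That floor alone does not show a gain beyond the scatter, and compound 2 gives a limit rather than a number: the limit of > 20000 nM in this assay, at which 1 of the 3 values shown sits.

The second new comparison holds dimethylamino fixed and changes only how the thiophene is attached to the shared core, with thiophen-2-yl in place of thiophen-3-yl, giving a 6.1-fold higher number from compound 1 to compound 3 (0.79 log units; beyond the scatter), which shows that this attachment point alone changes the number in a way the first two compounds, differing in more than one place, could not show.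

The compounds shown leave open how a plain amino group or a diethylamino group on this nitrogen would read, and whether a phenyl ring in place of the thiophene would give a number closer to that of compound 1. Also open, going by these compounds, is whether the step from methylamino to dimethylamino has the same size with thiophen-3-yl as with thiophen-2-yl.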